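From 3-ethoxyphenyl to 2-(trifluoromethyl)phenyl

A few compounds are considered here, and "the series" means these few. Any claim that something is new, unique, unknown or untested is made for them only; others in the source may bear on it.

In a functional assay on HL-60 cells (Homo sapiens) for inhibition, read by MTT assay, with a stated time of 72 h (a lower number here means a stronger inhibitor, a higher number a weaker inhibitor), compound 1 `C=C(C)c1ccc(N2CCN(C(=O)c3oc(C)nc3-c3ccccc3)CC2)cc1` is recorded as "not active" (no number reported), and compound 2 `COc1cccc(N2CCN(C(=O)c3oc(C)nc3-c3ccccc3)CC2)c1` gives 34.8 nM. Compound 3 `CCOc1cccc(N2CCN(C(=O)c3oc(C)nc3-c3ccccc3)CC2)c1`, at 151 nM, holds the higher of the two numbers. Compound 4 `Cc1nc(-c2ccccc2)c(C(=O)N2CCN(c3ccccc3C(F)(F)F)CC2)o1` has 2-(trifluoromethyl)phenyl in place of 3-ethoxyphenyl on an amine nitrogen in a ring. Going by the values given here, only one measured step touches this group, a 4.3-fold higher number from compound 2 to compound 3 (0.64 log units; beyond the scatter), and it alters the ether chain alone, so it guides the new change only loosely. Among the compounds with values here, no measured compound carries a trifluoromethyl group. In this assay a small move toward a higher number is expected, with no firm step beyond the scatter. The estimated change is a 1.7-fold higher number from compound 3 to compound 4 (0.22 log units; within the scatter). Compound 4 is expected at 250 nM, within a range of 40 nM to 1500 nM.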

Compound 4, half-maximal inhibitory concentration: 120 nM
Beside the measured number, compound 4's estimate is 2.1-fold (0.32 log units) above it; the range from low to high includes it.
By their numbers in this assay, from the lowest: compound 2; then compounds 4 and 3 (each within the scatter of the next).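

In this assay the exchange gives a 1.3-fold lower number from compound 3 to compound 4 (0.10 log units; within the scatter), so an aryl group with no hydrogen-bond acceptor stays level with the ethoxy compound on the ring nitrogen. Set against the methoxy compound, the same kind of exchange gives a 3.4-fold higher number from compound 2 to compound 4 (0.54 log units; beyond the scatter), and compound 2 keeps the lowest number of those shown. Nothing measured here accounts for either step. Going by these compounds alone, compound 4 is the only compound with a trifluoromethyl group, so one result stands for it. On these data alone, whether a phenyl ring bearing an amine or a carboxylic acid would match compound 2 remains open.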